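A few compounds are considered here, and "the series" means these few. Any claim that something is new, unique, unknown or untested is made for them only; others in the source may bear on it.

Measured compounds:
- compound 1 `CCCn1c(=O)[nH]c2nc(-c3ccc(S(=O)(=O)N4CCN(Cc5ccc(Br)cc5)CC4)cc3)[nH]c2c1=O` gives 31% in an assay on CHO cells for displacement of a labelled ligand from adenosine receptor A1 (Homo sapiens), read by scintillation counting, with a stated time of 90 min, tested at 1 uM, in the presence of a further agent that is not named here; a lower number here means less inhibition, a higher number more inhibition at the concentration tested (going by the name of the read-out)
- compound 2 `CCCn1c(=O)c2[nH]c(-c3ccc(S(=O)(=O)N4CCN(c5ccc(Cl)cc5)CC4)cc3)nc2n(C)c1=O` gives 22% in this assay

The two values lie within the usual scatter of each other, so compound 1 and compound 2 cannot be told apart on these numbers. Compound 3 `CCCn1c(=O)[nH]c2nc(-c3ccc(S(=O)(=O)N4CCN(c5ccc(I)cc5)CC4)cc3)[nH]c2c1=O` is not yet measured. It differs from compound 1 in one place: 4-iodophenyl in place of 4-bromobenzyl on an amine nitrogen in a ring. Within the data shown here, no measured pair shows what this change does, so the expected step of a number 6 percentage points lower from compound 1 to compound 3 (within the scatter) is small, if anything slightly downward, and not clearly beyond the scatter. Compound 3 is therefore expected to give about 25%, between 5% and 45%.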

Compound 3, a percentage reported as inhibition, at one concentration (the size of the read-out at that concentration, not a potency): 24%
For compound 3 the middle estimate is 1 percentage points above the measured one; the range from low to high includes it.
By their numbers in this assay, from the lowest: compounds 2, 3 and 1 (each within the scatter of the next).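

In this assay, putting 4-iodophenyl in place of 4-bromobenzyl on an amine nitrogen in a ring gives a number 7 percentage points lower from compound 1 to compound 3 (within the scatter). This first single-place comparison shows that this change, which replaces bromine with iodine and also alters the carbon count, leaves no distinguishable effect on the read-out. Nothing given here explains this result.

The two parts of the change remain unseparated, since 4-bromophenyl or 4-iodobenzyl does not appear among these compounds. As far as these compounds go, whether a carboxylic acid or a longer chain at this nitrogen moves the number beyond the scatter also remains open.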